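The source may report more compounds than this note shows. Statements on the series, on what has been measured and on what is new or still open speak of the compounds shown alone.

Compound 1 `COc1ccc(NC[C@H](O)COc2ccc(N3C[C@H](CNC(C)=O)OC3=O)cc2F)cc1` gives 0.95 in a physicochemical assay for lipophilicity, read by HPLC; on this read-out higher numbers stand for higher lipophilicity and lower numbers for lower lipophilicity; compound 2 `CC(=O)NC[C@H]1CN(c2ccc(OC[C@@H](O)CNc3cccnc3)c(F)c2)C(=O)O1` gives 0.02 in this assay; compound 3 `CC(=O)NC[C@H]1CN(c2ccc(OC[C@@H](O)CNC3CC3)c(F)c2)C(=O)O1` is not yet measured.

Within the data shown here, compound 2 stands lowest of the two measured numbers, with compound 1 as its only neighbour. Compound 3 differs from compound 2 by cyclopropyl in place of pyridin-3-yl on an amine nitrogen. Among the measured compounds shown here, the one measured step on the same amine nitrogen, a number 0.93 log units lower from compound 1 to compound 2 (beyond the scatter), bears on this change, though the entering group there was a different one. For compound 3 a further modest fall is expected, a number 0.52 log units lower from compound 2 to compound 3 (beyond the scatter). Compound 3 is therefore estimated at -0.5, between -1.3 and 0.3.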

Compound 3, partition coefficient: 0.02
Compound 3: middle estimate off by 0.52 log units, on the low side, and the stated range covers the measured number.
By their numbers in this assay, from the lowest: compounds 2 and 3 (each within the scatter of the next); then compound 1.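

In this assay, cyclopropyl in place of pyridin-3-yl on the amine nitrogen gives no change at the digits printed from compound 2 to compound 3 (within the scatter), so at this position a three-membered carbon ring and a six-membered aromatic ring with one hetero atom read alike. Measured against 4-methoxyphenyl, cyclopropyl gives a number 0.93 log units lower from compound 1 to compound 3 (beyond the scatter), a step of the same size as a number 0.93 log units lower from compound 1 to compound 2 (beyond the scatter). No measurement shown explains why these two groups read alike.

The compounds shown leave open whether an unsubstituted phenyl, a longer alkyl chain such as n-butyl, or a carboxylic acid on this amine nitrogen would give a similar number.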